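The source may hold more compounds than are shown below. What is called first, only, known or untested is meant among the compounds shown, and "the series" means these compounds.

Measured in a functional assay on MCF7 cells (Homo sapiens) for antiproliferative activity, read by MTT assay, with a stated time of 72 h; on this read-out lower numbers stand for stronger inhibition and higher numbers for weaker inhibition:
- compound 1 `CC1=CC[C@H]2[C@H](CC[C@]2(C)O)C(C)(C)[C@@H]1CC[C@H]1[C@]2(C)CC[C@H](OCc3ccccc3)C(C)(C)O[C@H]2CC[C@@]1(C)O` gives > 50000 nM, which is a limit of the assay
- compound 2 `CC1=CC[C@H]2[C@H](CC[C@]2(C)O)C(C)(C)[C@@H]1CC[C@H]1[C@]2(C)CC[C@H](OC(=O)c3ccc(F)cc3)C(C)(C)O[C@H]2CC[C@@]1(C)O` gives 33500 nM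
- compound 3 `CC1=CC[C@H]2[C@H](CC[C@]2(C)O)C(C)(C)[C@@H]1CC[C@H]1[C@]2(C)CC[C@H](OC(=O)c3ccc([N+](=O)[O-])cc3)C(C)(C)O[C@H]2CC[C@@]1(C)O` gives 21600 nM

For the measured compounds named here, compound 3 holds one of only two true numbers in this set, and it stands within the scatter of compound 2. Compound 4 `CC1=CC[C@H]2[C@H](CC[C@]2(C)O)C(C)(C)[C@@H]1CC[C@H]1[C@]2(C)CC[C@H](OC(=O)c3ccccc3F)C(C)(C)O[C@H]2CC[C@@]1(C)O` alters the aromatic group of compound 3, with 2-fluorophenyl in place of 4-nitrophenyl on a carbonyl carbon.

Going by the values given here, three measured steps bear on this change. Replacing benzyl with the two aryl carbonyl groups gave an at least 1.4-fold lower number from compound 1 to compound 2 (0.17 log units; that floor lies within the scatter) and an at least 2.3-fold lower number from compound 1 to compound 3 (0.36 log units; beyond the scatter), and compound 4 keeps the carbonyl. The closest guide is the exchange of fluoro and nitro, which gave a 1.6-fold lower number from compound 2 to compound 3 (0.19 log units; within the scatter). Among the compounds with values here, no measured compound shows what moving the fluoro group does. A step beyond the scatter is therefore not expected, and the number for compound 4 is expected to lean slightly upward, towards compound 2 at 33500 nM. The expected step is a 1.4-fold higher number from compound 3 to compound 4 (0.14 log units; within the scatter). In this assay the estimate for compound 4 is 30000 nM, with an expected range from 15000 nM to 50000 nM.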

Compound 4, half-maximal inhibitory concentration: 11300 nM
Estimate against measurement, compound 4: 2.7-fold (0.42 log units) above; measured number below the stated range.
By their numbers in this assay, from the lowest: compounds 4, 3 and 2 (each within the scatter of the next, the first and the last beyond it). At a limit, above all of these: compound 1.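

In this assay, for the compounds shown here, the place of the fluoro group matters for this pair: with 2-fluorophenyl in place of 4-fluorophenyl on the carbonyl carbon, the result is a 3.0-fold lower number from compound 2 to compound 4 (0.47 log units; beyond the scatter), a difference that the earlier compounds could not show. The change from 4-nitrophenyl is smaller, with a 1.9-fold lower number from compound 3 to compound 4 (0.28 log units; within the scatter), so compound 3 and compound 4 cannot be put in order, and the result does not separate the 2-fluorophenyl group from the 4-nitrophenyl group. With the carbonyl present and benzyl gone, the result is an at least 4.4-fold lower number from compound 1 to compound 4 (0.64 log units; beyond the scatter), but this size is only a floor because the starting value is a limit of the assay: the limit of > 50000 nM in this assay, at which 1 of the 4 values shown sits.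

The compounds shown leave open whether the difference between compound 2 and compound 4 belongs to fluoro itself or would also appear with another group in the same place, such as chloro, methoxy or nitro in a 2-substituted phenyl ring. They also leave open how a 3-fluorophenyl group would compare, and whether an amide link to the aromatic ring would behave like the ester link in compound 4.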